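Swapping bromo for methyl on the aromatic ring of compound 1

A few compounds are considered here, and "the series" means these few. Any claim that something is new, unique, unknown or untested is made for them only; others in the source may bear on it.

Measured compounds:
- compound 1 `O=C(CCCCCc1cccc(Br)c1)N1CCOC1=O`: 430 nM
- compound 2 `O=C(CCCCCc1ccc(Cl)cc1)N1CCOC1=O`: 4600 nM
- compound 3 `Nc1ccc(CCCCCC(=O)N2CCOC2=O)cc1`: 15700 nM

All three compounds share the same core and differ only in the group on the aromatic ring. In an assay on HEK293 cells for inhibition of N-acylethanolamine-hydrolyzing acid amidase (Rattus norvegicus), read by LC-MS, with a stated time of 30 min (on this read-out lower numbers stand for stronger inhibition and higher numbers for weaker inhibition), compound 1 gives 430 nM, the lowest of the three numbers and therefore the strongest inhibition; compound 2 gives 4600 nM and compound 3 gives 15700 nM. Going by the values given here, the only one-place step among the measured compounds is a 3.4-fold higher number from compound 2 to compound 3 (0.53 log units; beyond the scatter), an amino in place of chloro on an aromatic carbon.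

Compound 4 `Cc1cccc(CCCCCC(=O)N2CCOC2=O)c1` is not yet measured. It differs from compound 1 by methyl in place of bromo on an aromatic carbon. Among the compounds with values here, no measured step replaces bromo with methyl, and the step from compound 2 to compound 3 concerns a different group at a different place, so it bears only loosely on this change. The expected outcome in this assay is therefore uncertain, with a modest rise in the number considered most likely: compound 4 is estimated at 900 nM, in the range 300 nM to 3000 nM, which would mean an expected step of a 2.1-fold higher number from compound 1 to compound 4 (0.32 log units; beyond the scatter).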

Compound 4, half-maximal inhibitory concentration: 350 nM
Beside the measured number, compound 4's estimate is 2.6-fold (0.41 log units) above it, and the stated range covers the measured number.
By their numbers in this assay, from the lowest: compounds 4 and 1 (each within the scatter of the next); then compound 2; then compound 3.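

Methyl in place of bromo on this aromatic carbon, meta to a large group, gives a 1.2-fold lower number from compound 1 to compound 4 (0.09 log units; within the scatter) in this assay, so on this read-out the two groups cannot be told apart at this place. This is the first direct swap at this place among the compounds shown, and it indicates that bromine itself is not needed for a number of this size, since a single carbon in the same place serves as well. Nothing available says why the two groups read alike.

Still open, on these data alone, is whether a larger or different group at this same place, such as methoxy, ethyl or a carboxylic acid, would keep the number or shift it. Also open, as far as these compounds go, is whether methyl would read the same on another carbon of the ring.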